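Swapping nitro for fluoro on a weak chalcone-like pair

The compounds below may be only part of what the source reports. "The series", "measured", "known", "first", "only" and "open" are said of these compounds alone.

Of the compounds shown here, two of a shared core have been measured in a functional assay on K562 cells (Homo sapiens) for antiproliferative activity, read by MTT assay, with a stated time of 5 days; on this read-out higher numbers stand for weaker inhibition and lower numbers for stronger inhibition. Compound 1, `COc1ccc(C=C(C(=O)c2cc(OC)c(OC)c(OC)c2)c2ccccc2)cc1F`, gives 790000 nM in this assay. Going by the values given here, compound 2, `COc1ccc(C=C(C(=O)c2cc(OC)c(OC)c(OC)c2)c2ccc(C)cc2)cc1[N+](=O)[O-]`, gives 2430000 nM in this assay, the highest of the two numbers, and the only comparison available puts compound 1 at a lower number, beyond the scatter. The two compounds differ in more than one place, so their gap cannot be assigned to a single change.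

Compound 3, `COc1ccc(C=C(C(=O)c2cc(OC)c(OC)c(OC)c2)c2ccc(C)cc2)cc1F`, has not yet been measured. It differs from compound 2 by fluoro in place of nitro on an aromatic carbon. Compound 3 shares its fluoro-bearing ring with compound 1 and its methyl-bearing ring with compound 2.

Because compound 1 gives 790000 nM with the same fluoro and methoxy pattern, compound 3 is expected to sit nearer to compound 1 than to compound 2, and the step of a 2.7-fold lower number from compound 2 to compound 3 (0.43 log units; beyond the scatter) is expected to lower the number by an amount modestly beyond the scatter. The estimate for compound 3 in this assay is 900000 nM, within a range from 300000 nM to 3000000 nM.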

Compound 3, half-maximal inhibitory concentration: 570000 nM
Compound 3: the middle estimate sits 1.6-fold (0.20 log units) above what was measured, and the stated range covers the measured number.
By their numbers in this assay, from the lowest: compounds 3 and 1 (each within the scatter of the next); then compound 2.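

In this assay, the change from 4-methoxy-3-nitrophenyl to 3-fluoro-4-methoxyphenyl can now be read on its own: fluoro in place of nitro gives a 4.3-fold lower number from compound 2 to compound 3 (0.63 log units; beyond the scatter), so this place on the ring, ortho to the methoxy group, does respond to the exchange, by a modest step beyond the scatter. Going by these compounds alone, the second single change behaves differently, since methyl in place of hydrogen on the other aromatic ring gives a 1.4-fold lower number from compound 1 to compound 3 (0.14 log units; within the scatter), which lies within the scatter; of the two changes that separate the earlier compounds, only the exchange of nitro for fluoro produces a step beyond it. Nothing available explains why the exchange moves the number.

The compounds shown leave open whether an amine or a hydroxyl group at the same place would move the number further, and in which direction. They also leave open whether fluoro in place of nitro gives a step of similar size with hydrogen in place of the methyl, and whether an ethyl group would behave as the methyl does.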